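Swapping Methoxy for Chloro in a Cytotoxicity Series

The source may hold more compounds than are shown below. What is called first, only, known or untested is meant among the compounds shown, and "the series" means these compounds.

Compound 1 `COc1ccc(/C=C/C(=O)c2cccc(-c3cccc(F)c3)c2)cc1`: 740 nM
Compound 2 `COc1ccc(/C=C/C(=O)c2cccc(-c3cccc(F)c3)c2)cc1OC`: 770 nM
Compound 3 `COc1ccc(/C=C/C(=O)c2cccc(-c3cccc(F)c3)c2)cc1O`: "not determined" (no result reported)

In a functional assay on CNE-2 cells (Homo sapiens) for cytotoxicity, read by sulforhodamine B assay, with a stated time of 48 h (on this read-out higher numbers stand for weaker inhibition and lower numbers for stronger inhibition), compound 1 gives 740 nM, and compound 2 gives 770 nM; the two stand within the scatter of each other, differing by a 1.0-fold higher number from compound 1 to compound 2 (0.02 log units; within the scatter) after methoxy in place of hydrogen on an aromatic carbon. Compound 3 has no number. Compound 4 `O=C(/C=C/c1ccc(Cl)cc1)c1cccc(-c2cccc(F)c2)c1` differs from compound 1 by chloro in place of methoxy on an aromatic carbon. Going by the values given here, no measured step involves a chloro group, so the only guide is that the single change made so far on an aromatic carbon left the number essentially unmoved. Compound 4 is therefore expected to stay close to compound 1, with a step of no change at the digits printed from compound 1 to compound 4 (within the scatter) expected to remain within the scatter. The estimate for compound 4 is 740 nM, ranging from 300 nM to 1800 nM.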

Compound 4, half-maximal inhibitory concentration: 9060 nM
Compound 4: middle estimate off by 12-fold (1.09 log units), on the low side, and the stated range ends below it.
By their numbers in this assay, from the lowest: compounds 1 and 2 (each within the scatter of the next); then compound 4.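

In this assay, replacing 4-methoxyphenyl with 4-chlorophenyl gives a 12-fold higher number from compound 1 to compound 4 (1.09 log units; beyond the scatter) and so costs far more than the earlier methoxy change, which gave a 1.0-fold higher number from compound 1 to compound 2 (0.02 log units; within the scatter) and left the number essentially unmoved. This position is therefore sensitive to which group it carries, and a quiet step elsewhere on the ring does not predict what happens here. Nothing measured here explains the difference. On these data alone, whether losing methoxy or gaining chloro drives the step remains open. So does how a fluoro, methyl or dimethylamino group would read at this position.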